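This account rests on a few compounds, and the source may have more. Where it says the series, first, only, none or still open, it means among the compounds named here.

Working notes on the series, read in a functional assay on A549 cells (Homo sapiens) for antiproliferative activity, read by MTT assay, with a stated time of 72 h; a higher number here means a weaker inhibitor, a lower number a stronger inhibitor. Compound 1 `COc1cc(C(=O)c2sc3ccccc3c2-c2ccc(C)cc2)cc(OC)c1OC` gives 7800 nM, and compound 2 `COc1cc(C(=O)c2sc3ccccc3c2Nc2ccc(C)cc2)cc(OC)c1OC` gives 2600 nM. Compound 2 therefore holds the lower of the two numbers and serves as the reference for the next change.

Compound 3 `COc1cc(C(=O)c2sc3cc(C)ccc3c2Nc2ccc(C)cc2)cc(OC)c1OC` differs from it by methyl in place of hydrogen on an aromatic carbon of a six-membered aromatic ring of carbon only, part of a fused or bridged system of two rings.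

Within the data shown here, only one measured step exists, a 3.0-fold lower number from compound 1 to compound 2 (0.48 log units; beyond the scatter). It is modest and beyond the scatter, but it concerns (4-methylphenyl)amino in place of 4-methylphenyl, a change at a different place. The data hold no measured step for a methyl on this ring, so neither its size nor its direction is shown. No step beyond the scatter is expected, and compound 3 is expected to stay close to compound 2 at 2600 nM.

The estimated step is a 1.2-fold lower number from compound 2 to compound 3 (0.07 log units; within the scatter). For compound 3 the expected value is 2200 nM, with an estimated range of 800 nM to 6500 nM.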

Compound 3, half-maximal inhibitory concentration: 1900 nM
Compound 3: the middle estimate sits 1.2-fold (0.06 log units) above what was measured; low and high end bracket the measured number.
By their numbers in this assay, from the lowest: compounds 3 and 2 (each within the scatter of the next); then compound 1.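

In this assay, among these compounds, methyl in place of hydrogen on an aromatic carbon of the six-membered aromatic ring of carbon only gives a 1.4-fold lower number from compound 2 to compound 3 (0.14 log units; within the scatter), the first measured step at this position. Compound 2 and compound 3 therefore cannot be told apart in this read-out, and this place on the shared core accepts a methyl without a readable loss or gain. Among the compounds shown here, the only step beyond the scatter remains a 3.0-fold lower number from compound 1 to compound 2 (0.48 log units; beyond the scatter), which lies at a different place, so the two steps show that the change in the group on the aromatic carbon registers here while this methyl does not. No measurement at hand bears on the reason for this result.

On these data alone, a single small group says little about the position as a whole, so it remains open whether a longer chain such as propyl, an amine or a carboxylic acid at the same carbon would also stay within the scatter of compound 2. As far as these compounds go, it also remains open whether a methyl on the other carbons of this ring would behave as it does in compound 3.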